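This account rests on a few compounds, and the source may have more. Where it says the series, first, only, none or still open, it means among the compounds named here.

Measured compounds:

- compound 1 `COc1cc(-c2cc(/C=C/C(=O)c3ccc(N)cc3)[nH]n2)cc(OC)c1OC`: in a functional assay on HCC 2998 cells (Homo sapiens) for cytotoxicity, read by sulforhodamine B assay, with a stated time of 48 h, tested at 0.01 uM (on this read-out lower numbers stand for a stronger effect and higher numbers for a weaker effect at the one concentration tested), compound 1 gives 108%
- compound 2 `COc1ccc(-c2cc(/C=C/C(=O)c3ccc(N)cc3)[nH]n2)cc1OC`: compound 2 gives 102%
- compound 3 `COc1ccc(-c2cc(/C=C/C(=O)c3cc(OC)c(OC)c(OC)c3)[nH]n2)cc1OC`: compound 3 gives 95%

Of these three numbers, that of compound 1 is the highest. The difference to compound 2 is a number 6 percentage points lower from compound 1 to compound 2 (within the scatter), so these two cannot be told apart. Compound 3 sits further away, and its number is lower by a gap beyond the scatter.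

Compound 4 `COc1ccc(C(=O)/C=C/c2cc(-c3cc(OC)c(OC)c(OC)c3)n[nH]2)cc1` is not yet measured. It differs from compound 1 in one place: methoxy in place of amino on an aromatic carbon. Among the compounds with values here, none of the measured steps concerns this change; the only single-point step, from compound 1 to compound 2, swaps a methoxy for hydrogen elsewhere and stayed within the scatter. With no direct evidence, and with all three measured numbers lying close to a value that marks no effect at the tested concentration, the step of a number 8 percentage points lower from compound 1 to compound 4 (within the scatter) is expected to stay within the scatter. Compound 4 is therefore estimated at 100%, with a range from 85% to 115%.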

Compound 4, a percentage reported as activity, at one concentration (the size of the read-out at that concentration, not a potency): 101%
Estimate against measurement, compound 4: 1 percentage points below; measured number inside the range.
By their numbers in this assay, from the lowest: compounds 3, 4, 2 and 1 (each within the scatter of the next, the first and the last beyond it).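

Within the data shown here, the 4-aminophenyl of compound 1 is the first part of the molecule seen to change at this position, and in this assay exchanging it for 4-methoxyphenyl gives a number a number 7 percentage points lower from compound 1 to compound 4 (within the scatter). So at this single concentration, an amino group with its hydrogen-bond donor and a larger methoxy group without one cannot be told apart on this ring, although a flat result this close to no effect says little about how much the position matters. Nothing available here offers an explanation for this outcome.

Going by these compounds, whether a hydroxyl group, a carboxylic acid or a longer chain such as butoxy at this place would move the number beyond the scatter stays open. Also open, on these data alone, is whether amino and methoxy would still match at a concentration where these compounds show a clear effect.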